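The compounds below may be only part of what the source reports. "The series", "measured", "known", "first", "only" and "open" are said of these compounds alone.

Compound 1 (`COc1ccc(C2=NOC(COc3ccc(-c4nnnn4-c4cc(OC)c(OC)c(OC)c4)cc3N)C2)cc1N`) gives 3000 nM in a functional assay on MDA-MB-231 cells (Homo sapiens) for cytotoxicity, read by MTT assay, with a stated time of 48 h (on this read-out higher numbers stand for weaker inhibition and lower numbers for stronger inhibition), and has one measured neighbour, compound 2 (`COc1cc(-n2nnnc2-c2ccc(OCC3CC(c4ccc(C(F)(F)F)cc4)=NO3)c(N)c2)cc(OC)c1OC`), which gives 1750 nM there. The gap between them is small (a 1.7-fold lower number from compound 1 to compound 2 (0.23 log units; within the scatter)), so these two numbers cannot be told apart.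

Compound 3 (`COc1cc(-n2nnnc2-c2ccc(OCC3CC(c4ccc(OC)c(OC)c4OC)=NO3)c(N)c2)cc(OC)c1OC`) keeps the core of compound 1 and differs from it in one group (2,3,4-trimethoxyphenyl in place of 3-amino-4-methoxyphenyl on a carbon with a double bond to nitrogen). In words, 2,3,4-trimethoxyphenyl replaces 3-amino-4-methoxyphenyl on a carbon with a double bond to nitrogen. Going by the values given here, the only measured step at this place is the one to compound 2, where 4-(trifluoromethyl)phenyl replaces the same group. Among the compounds with values here, that single step (a 1.7-fold lower number from compound 1 to compound 2 (0.23 log units; within the scatter)) involves a different incoming group from the one in compound 3, so it is thin evidence. Still, it offers no ground for foreseeing a large shift, and no step beyond the scatter, in either direction, is expected in this assay from this change.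

The expected change is therefore small (a 1.4-fold lower number from compound 1 to compound 3 (0.13 log units; within the scatter)). Compound 3 is expected at 2200 nM with an estimated range of 800 nM to 6000 nM on this measure.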

Compound 3, half-maximal inhibitory concentration: 3540 nM
For compound 3 the middle estimate is 1.6-fold (0.21 log units) below the measured one, and the stated range covers the measured number.
By their numbers in this assay, from the lowest: compounds 2, 1 and 3 (each within the scatter of the next, the first and the last beyond it).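

In this assay, this position on a carbon with a double bond to nitrogen now carries three different groups, and 2,3,4-trimethoxyphenyl in place of 3-amino-4-methoxyphenyl gives a 1.2-fold higher number from compound 1 to compound 3 (0.07 log units; within the scatter), so the two cannot be told apart, even though the entering group has more heavy atoms and no hydrogen-bond donor. Comparing the two incoming groups, 2,3,4-trimethoxyphenyl in place of 4-(trifluoromethyl)phenyl gives a 2.0-fold higher number from compound 2 to compound 3 (0.31 log units; beyond the scatter), the first step at this position to lie beyond the scatter, though only modestly. Nothing available explains either result.

All three groups at this position are substituted phenyl rings, so the compounds shown leave open whether a plain phenyl, a carboxylic acid or an open alkyl chain placed there would move the number much further in either direction. They also leave open which part of the 2,3,4-trimethoxyphenyl group accounts for the modest step, since a phenyl ring with a single methoxy group is not among them.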